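Moving the Carboxyl Group Around the Phenoxy Ring

A few compounds are considered here, and "the series" means these few. Any claim that something is new, unique, unknown or untested is made for them only; others in the source may bear on it.

Compound 1 `Cc1c(OCCCCOc2cccc(C(=O)O)c2)ccc(C(=O)CC(C)C)c1C` shows no measurable effect in an assay on HEK293 cells for positive allosteric modulation of metabotropic glutamate receptor 2 (Rattus norvegicus), read by thallium flux, with a stated time of 2.5 min; a lower number here means that less compound is needed, a higher number that more compound is needed for the effect: it is recorded as "not active" (no number reported), and no number stands for it. Compound 2 `Cc1c(OCCCCOc2cccc(C(=O)O)c2)ccc(C(=O)CC(C)C)c1O` shares the linker and core of compound 1; in this assay compound 2 gives 222 nM, so a close relative does reach a measurable value. The unmeasured compound 3 `Cc1c(OCCCCOc2ccccc2C(=O)O)ccc(C(=O)CC(C)C)c1C` is drawn from compound 1 by a single rearrangement (2-carboxyphenyl in place of 3-carboxyphenyl on an oxygen on a saturated carbon). For the measured compounds named here, compound 1 has no number, so no step can be counted and a direction can only be guessed. Starting from an inactive compound, this change offers nothing in the available numbers that would point to a measurable effect; the likeliest outcome is again no number at all. Should a value appear, compound 3 is expected to fall near 20000 nM, with a range from 3000 nM to 100000 nM.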

Compound 3, half-maximal effective concentration: 976 nM
Compound 3: the middle estimate sits 20-fold (1.31 log units) above what was measured; the whole stated range lies above it.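

In this assay, for the compounds shown here, compound 3 gives 976 nM while compound 1 has no number, so no step between compound 1 and compound 3 can be read. Nothing measured here bears on the reason for this result. The compounds shown leave open how large the difference between 3-carboxyphenyl and 2-carboxyphenyl is on this core.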